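This account rests on a few compounds, and the source may have more. Where it says the series, first, only, none or still open, it means among the compounds named here.

Going by the values given here, compound 2 `Cc1cc(-c2cc(Cl)cc(Cl)c2)c(S(C)(=O)=O)cc1C(=O)N=C(N)N` gives 130 nM in a functional assay for inhibition of sodium/hydrogen exchanger (Oryctolagus cuniculus) (a lower number here means a stronger inhibitor, a higher number a weaker inhibitor), the higher of the two numbers measured so far; compound 1 `Cc1cc(Cl)c(S(C)(=O)=O)cc1C(=O)N=C(N)N` gives 25 nM, and a 5.2-fold higher number from compound 1 to compound 2 (0.72 log units; beyond the scatter). Compound 3 `CCCSc1cc(C)c(C(=O)N=C(N)N)cc1S(C)(=O)=O` differs from compound 2 by propylsulfanyl in place of 3,5-dichlorophenyl on an aromatic carbon. Among the compounds with values here, no measured step covers propylsulfanyl, so only the change from chloro to 3,5-dichlorophenyl bears on it, and that step was modest. A number between those of compound 1 and compound 2 is expected. The step of a 2.6-fold lower number from compound 2 to compound 3 (0.41 log units; beyond the scatter) is thus estimated. Compound 3 is expected at 50 nM, with a range from 15 nM to 170 nM.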

Compound 3, half-maximal inhibitory concentration: 6.8 nM
The estimate for compound 3 lay 7.4-fold (0.87 log units) above the measured number; measured number outside the range, below it.
By their numbers in this assay, from the lowest: compound 3; then compound 1; then compound 2.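

In this assay the position proves able to give a lower number than chloro, not only a higher one. Propylsulfanyl in place of 3,5-dichlorophenyl gives a 19-fold lower number from compound 2 to compound 3 (1.28 log units; beyond the scatter) and propylsulfanyl in place of chloro gives a 3.7-fold lower number from compound 1 to compound 3 (0.57 log units; beyond the scatter), so the loss seen with the aryl group does not apply to every larger substituent. Nothing available accounts for this difference.

As far as these compounds go, whether a shorter chain such as ethylsulfanyl, a longer one such as butylsulfanyl, or an amine on this carbon would go lower still remains open. So does whether the sulfur matters, which a propoxy or butyl group would test.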